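The source may report more compounds than this note shows. Statements on the series, on what has been measured and on what is new or still open speak of the compounds shown alone.

Compound 1 `O=S(=O)(Nc1ccc(-c2nc3ccccc3o2)cc1)c1cccc(Cl)c1` holds the lowest of the two numbers recorded in an assay on cells for inhibition of HSP60/HSP10 (Homo sapiens), with a stated time of 60 min (a higher number here means a weaker inhibitor, a lower number a stronger inhibitor), giving 54000 nM. Compound 2 `O=S(=O)(Nc1ccc2oc(-c3ccccc3)nc2c1)c1ccc(F)c(C(F)(F)F)c1` gives 69000 nM in this assay, a value within the scatter of compound 1, so the two cannot be ranked. Compound 3 `O=S(=O)(Nc1ccc2oc(-c3ccccc3)nc2c1)c1cccc(F)c1` gives only a limit of this assay, > 100000 nM, and no number.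

Compound 4 `CS(=O)(=O)Nc1ccc(-c2nc3ccccc3o2)cc1` is the next step from compound 1, with the change (methyl in place of 3-chlorophenyl on a sulfonyl sulfur). Among the measured compounds shown here, no measured pair shows what this kind of change does here, so the step from compound 1 to compound 4 is expected to be a 1.6-fold higher number from compound 1 to compound 4 (0.20 log units; within the scatter), a shift that may not rise beyond the scatter. Compound 4 is therefore estimated to give 85000 nM in this assay, with a likely range from 30000 nM to 250000 nM.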

Compound 4, half-maximal inhibitory concentration: > 100000 nM
Compound 4: a limit, no number; the forecaster's own chance of this, stated with the estimate: 40%; middle value at least 1.1-fold (0.07 log units) away from the limit.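

Replacing 3-chlorophenyl with methyl on the sulfonyl sulfur gives an at least 1.8-fold higher number from compound 1 to compound 4 (0.26 log units; that floor lies within the scatter) in this assay. This first step at this position does not show a loss beyond the scatter, but it does not rule out a larger one. Its true size stays unknown, because compound 4 reaches only a limit of the assay: the limit of > 100000 nM in this assay, at which 2 of the 4 values shown sit.

Still open, on these data alone, is whether an unsubstituted phenyl on the sulfonyl sulfur would keep the number of compound 1 or join compound 4 at the limit. A longer chain such as butyl, or a benzyl group, could show how much of the 3-chlorophenyl group is needed.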